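A few compounds are considered here, and "the series" means these few. Any claim that something is new, unique, unknown or untested is made for them only; others in the source may bear on it.

Measured in a functional assay on HeLa cells (Homo sapiens) for antiproliferative activity, read by MTT assay, with a stated time of 48 h; on this read-out higher numbers stand for weaker inhibition and lower numbers for stronger inhibition:
- compound 1 `COc1cc(-c2nnc3c(OC4COC4)cc(-c4ccc5[nH]ccc5c4)cn23)cc(OC)c1OC`: 2780 nM
- compound 2 `COc1cc(-c2nnc3c(OCC(F)(F)F)cc(-c4ccc5[nH]ccc5c4)cn23)cc(OC)c1OC`: 348 nM
- compound 3 `COc1cc(-c2nnc3c(OC4CN(C(C)(C)C)C4)cc(-c4ccc5[nH]ccc5c4)cn23)cc(OC)c1OC`: > 10000 nM (a limit of the assay, not a number)

Of the two actual numbers, the higher belongs to compound 1, at 2780 nM. Its nearest neighbour is compound 2, through an 8.0-fold lower number from compound 1 to compound 2 (0.90 log units; beyond the scatter). The third result, for compound 3, is only a limit.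

Compound 4 `COc1cc(-c2nnc3c(OC4COC4)cc(-c4ccc5c(ccn5C)c4)cn23)cc(OC)c1OC` keeps the group on the oxygen of compound 1 and changes the other end of the molecule: methyl in place of hydrogen on an aromatic nitrogen. This is methyl in place of hydrogen on an aromatic nitrogen, 1H-indol-5-yl becoming 1-methyl-1H-indol-5-yl.

Going by the values given here, no measured step touches that nitrogen. All three exchange the group on the oxygen on an aromatic ring: an 8.0-fold lower number from compound 1 to compound 2 (0.90 log units; beyond the scatter), which is modest; an at least 3.5-fold higher number from compound 1 to compound 3 (0.55 log units; beyond the scatter), at least modest; and an at least 28-fold higher number from compound 2 to compound 3 (1.45 log units; beyond the scatter), which is large. They show that the series can respond strongly to a change elsewhere, but they give neither size nor direction for this one.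

No step beyond the scatter is therefore expected in this assay, and the range is kept wide on both sides. Among the compounds with values here, the only anchor is compound 1 at 2780 nM. The expected change is a 1.1-fold lower number from compound 1 to compound 4 (0.05 log units; within the scatter). Compound 4 is estimated at 2500 nM, with an expected range of 700 nM to 9000 nM.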

Compound 4, half-maximal inhibitory concentration: 214 nM
Compound 4: middle estimate off by 12-fold (1.07 log units), on the high side; the measured number lies below the stated range.
By their numbers in this assay, from the lowest: compounds 4 and 2 (each within the scatter of the next); then compound 1. At a limit, above all of these: compound 3.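

Working notes on the aromatic nitrogen of the 1H-indol-5-yl group: in this assay methyl in place of hydrogen is a large change (a 13-fold lower number from compound 1 to compound 4 (1.11 log units; beyond the scatter)), so this end of the molecule is a second place at which the series responds, alongside the group on the oxygen. In this pair the hydrogen on that nitrogen is not required for the lower number, and a single added carbon, with the oxetan-3-yl group held constant, is enough to move the result beyond the scatter. Nothing measured for these compounds accounts for the size or direction of this step.

Going by these compounds, it remains open whether the same exchange on the nitrogen gives a step of similar size and direction when the oxygen carries the 2,2,2-trifluoroethyl group of compound 2 or the 1-(tert-butyl)azetidin-3-yl group of compound 3. Also open, on these data alone, is how far this position tolerates more than methyl, for instance a longer chain such as ethyl or propyl, a 2-hydroxyethyl group, or an acetyl group on the same nitrogen.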